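Swapping (piperidin-1-yl)carbonyl for (dimethylcarbamoyl)methyl in compound 3

The compounds below may be only part of what the source reports. "The series", "measured", "known", "first", "only" and "open" are said of these compounds alone.

Compound 1 `CCN(CC)C(=O)Cn1c(-c2ccc(Cl)cc2)nc2cccnc21` gives 16 mg/kg
Compound 2 `O=C(Cn1c(-c2ccc(Cl)cc2)nc2cccnc21)N1CCCC1` gives 17.9 mg/kg
Compound 3 `O=C(Cn1c(-c2ccc(Cl)cc2)nc2cccnc21)N1CCCCC1` gives 56.2 mg/kg

These three compounds were tested in a functional assay on the whole organism with Mus musculus as the target (on this read-out lower numbers stand for an effect already at smaller amounts and higher numbers for an effect only at larger amounts of compound), and differ only in the amine on the carbonyl. Compound 3 has the highest number of the three, and both of its steps lie beyond the scatter: a 3.5-fold higher number from compound 1 to compound 3 (0.55 log units; beyond the scatter) and a 3.1-fold higher number from compound 2 to compound 3 (0.50 log units; beyond the scatter). Compounds 1 and 2 do not separate, with a 1.1-fold higher number from compound 1 to compound 2 (0.05 log units; within the scatter).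

The next compound is compound 4 `CN(C)C(=O)CCn1c(-c2ccc(Cl)cc2)nc2cccnc21`. The change is (dimethylcarbamoyl)methyl in place of (piperidin-1-yl)carbonyl on a saturated chain carbon bound to an aromatic nitrogen.

The measured steps bear on only part of this change. Compound 4 gives up the piperidin-1-yl ring, and compound 1, which has no such ring, points to a lower number through a 3.5-fold higher number from compound 1 to compound 3 (0.55 log units; beyond the scatter). Among the measured compounds shown here, no measured compound carries the (dimethylcarbamoyl)methyl group, so the effect of this group is unknown and could cancel that modest gain. On balance, no step beyond the scatter is expected, and the expected change is a 1.4-fold lower number from compound 3 to compound 4 (0.15 log units; within the scatter). For compound 4 the estimated value is 40 mg/kg, within an expected range from 13 mg/kg to 120 mg/kg.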

Compound 4, dose for half-maximal effect: 29.4 mg/kg
Estimate against measurement, compound 4: 1.4-fold (0.13 log units) above; measured number inside the range.
By their numbers in this assay, from the lowest: compounds 1, 2, 4 and 3 (each within the scatter of the next, the first and the last beyond it).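

In this assay, the step of a 1.9-fold lower number from compound 3 to compound 4 (0.28 log units; within the scatter) stays within the scatter, so giving up the (piperidin-1-yl)carbonyl group for (dimethylcarbamoyl)methyl on a saturated chain carbon bound to an aromatic nitrogen does not separate the two compounds. The same holds for the steps of a 1.6-fold higher number from compound 2 to compound 4 (0.22 log units; within the scatter) and a 1.8-fold higher number from compound 1 to compound 4 (0.26 log units; within the scatter), so compound 4 does not separate from any of the three earlier amides, even though compound 3 separates from both compound 1 and compound 2. This position therefore accepts an open-chain group that has no ring and still gives a number in the range already seen, but no available evidence accounts for this result.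

The compounds shown leave open how the dimethylcarbamoyl part and the methyl part of the entering group each contribute, as the two change together in this one step; a (piperidin-1-yl)carbonylmethyl group would separate them. They also leave open how a carboxylic acid or a primary amide at this place would read out in this assay.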